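The source may hold more compounds than are shown below. What is called first, only, known or untested is meant among the compounds shown, and "the series" means these compounds.

Measured so far in a functional assay on CHO cells for agonist activity at Free fatty acid receptor 1 (Homo sapiens), read by FLIPR and calcium flux, tested at 100 nM; a higher number here means a stronger effect of the compound at the concentration tested, a lower number a weaker effect:
compound 1, `Cc1nc(-c2ccc(F)cc2)sc1COc1ccc2c(c1)OCC2CC(=O)O` — 61.6%
compound 2, `Cc1nc(-c2ccccc2C(F)(F)F)sc1COc1ccc2c(c1)OCC2CC(=O)O` — 7.76%

Among the compounds with values here, compound 2 is the lower of the two numbers; its nearest neighbour is compound 1, and the only measured step, a number 53.8 percentage points lower from compound 1 to compound 2 (beyond the scatter), is the one that separates them. Compound 3, `Cc1nc(-c2cccc(C(F)(F)F)c2)sc1COc1ccc2c(c1)OCC2CC(=O)O`, is not yet measured. It differs from compound 2 as follows: 3-(trifluoromethyl)phenyl in place of 2-(trifluoromethyl)phenyl on an aromatic carbon. Within the data shown here, the one step in hand bears on it only indirectly: it shows that the pattern on the phenyl ring attached to the shared core can move the read-out by a large amount, since a 4-fluorophenyl gives a high value and a 2-(trifluoromethyl)phenyl a low one. Among the measured compounds shown here, no measured pair tells how a 3-(trifluoromethyl)phenyl behaves, so the direction of the step from compound 2 is uncertain, but the room above compound 2 is large and the room below it small. Compound 3 is therefore estimated at 32%, with a range of 8% to 62%. The step that this estimate means is expected to be a number 24.2 percentage points higher from compound 2 to compound 3 (beyond the scatter), which is beyond the scatter yet smaller than the drop already seen.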

Compound 3, a percentage reported as activity, at one concentration (the size of the read-out at that concentration, not a potency): 35.7%
The estimate for compound 3 lay 3.7 percentage points below the measured number; the measured number falls inside the stated range.
By their numbers in this assay, from the lowest: compound 2; then compound 3; then compound 1.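

Moving the trifluoromethyl group around the phenyl ring, with the atoms otherwise unchanged, is enough to shift the read-out in this assay: a number 27.9 percentage points higher from compound 2 to compound 3 (beyond the scatter), so the mere presence of a trifluoromethyl group does not fix the result at this position. The 3-(trifluoromethyl)phenyl group still does not match the 4-fluorophenyl group, with a number 25.9 percentage points lower from compound 1 to compound 3 (beyond the scatter), although that step changes both the substituent and its place on the phenyl ring and so cannot be assigned to either alone. No supporting data are available to explain these differences.

The compounds shown do not separate the place of the substituent from its identity: a 4-(trifluoromethyl)phenyl group would be a one-change partner for both compound 1 and compound 3, and would test whether the place on the phenyl ring or the choice of fluorine or trifluoromethyl matters more. Also open, going by these compounds, is how a phenyl ring carrying a methoxy group, a nitrile or an amine would read at this same aromatic carbon on the shared core.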